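Chloro Exchanged for tert-Butyl in an Acetyl Ester Series

The source may hold more compounds than are shown below. What is called first, only, known or untested is meant among the compounds shown, and "the series" means these compounds.

In an ADME assay on L6 cells (Rattus norvegicus) for cytotoxicity, read by resazurin assay, with a stated time of 70 h (on this read-out higher numbers stand for weaker inhibition and lower numbers for stronger inhibition), compound 1 (`CC1=CC(C)(C)N(Cc2ccc(Cl)cc2)c2ccc(O)cc21`) reads 7900 nM and compound 2 (`CC(=O)Oc1ccc2c(c1)C(C)=CC(C)(C)N2Cc1ccc(Cl)cc1`) reads 22000 nM while compound 3 (`CC(=O)Oc1ccc2c(c1)C(C)=CC(C)(C)N2Cc1cccc(Cl)c1`) reads 29000 nM on the same scale. Compound 2 thus stands within the scatter of compound 3 and beyond the scatter from compound 1. Compound 4 (`CC(=O)Oc1ccc2c(c1)C(C)=CC(C)(C)N2Cc1ccc(C(C)(C)C)cc1`) is still unmeasured and differs from compound 2 by one exchange (tert-butyl in place of chloro on an aromatic carbon), tert-butyl in place of chloro on an aromatic carbon. Among the measured compounds shown here, no measured step makes this exchange. The closest, 3-chlorophenyl in place of 4-chlorophenyl, gave a 1.3-fold higher number from compound 2 to compound 3 (0.12 log units; within the scatter) and stayed within the scatter. The acetyl step gave a 2.8-fold higher number from compound 1 to compound 2 (0.44 log units; beyond the scatter) and was modest, but it lies elsewhere on the molecule. Neither sets a direction, so no step beyond the scatter is expected in this assay for this exchange. The expected change is small (a 1.1-fold lower number from compound 2 to compound 4 (0.04 log units; within the scatter)) in either direction. Compound 4 is estimated at 20000 nM with an expected range of 8000 nM to 50000 nM in this measurement.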

Compound 4, half-maximal inhibitory concentration: 9000 nM
The estimate for compound 4 lay 2.2-fold (0.35 log units) above the measured number, and the stated range covers the measured number.
By their numbers in this assay, from the lowest: compounds 1 and 4 (each within the scatter of the next); then compounds 2 and 3 (each within the scatter of the next).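

Exchanging chloro for tert-butyl on this aromatic carbon gave a 2.4-fold lower number from compound 2 to compound 4 (0.39 log units; beyond the scatter) in this assay and so moved the number toward stronger inhibition. Moving the chlorine had given only a 1.3-fold higher number from compound 2 to compound 3 (0.12 log units; within the scatter) and had left the read-out within the scatter, so this is the first change on this ring shown to move the number beyond it. No measurement shown offers a reason for the shift.

Going by these compounds, whether a methyl, an isopropyl or a trifluoromethyl group on this aromatic carbon would move the number the same way remains open. On these data alone, it also remains open whether tert-butyl would give a similar step with the free hydroxyl of compound 1 in place of the acetyl ester.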